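Phenyl series: methyl removal on the aryl ring

This account rests on a few compounds, and the source may have more. Where it says the series, first, only, none or still open, it means among the compounds named here.

Measured so far:
Compound 1, `O=S(=O)(CC1=NCCO1)c1n[nH]cc1-c1ccccc1`, 57.5% in a functional assay, read by Griess assay, with a stated time of 150 min, tested at 100 ug/mL; a higher number here means a stronger effect of the compound at the concentration tested, a lower number a weaker effect
Compound 2, `O=S(=O)(CC1=NCCS1)c1n[nH]cc1-c1ccc(Cl)cc1`, "not active" (no number reported)
Compound 3, `Cc1ccc(-c2c[nH]nc2S(=O)(=O)CC2=NCCS2)cc1`, "not active" (no number reported)

In this assay compound 3 gives "not active" (no number reported), so no number stands for it, and the same holds for compound 2 with "not active" (no number reported). Among the measured compounds only compound 1 gives a number, 57.5%; compound 1 carries the plain phenyl group but differs from the other two at another site, and no step between it and any of them is computed here, so its value is taken only as showing that this arrangement can give a sizeable read-out.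

The step followed is from compound 3 to compound 4, `O=S(=O)(CC1=NCCS1)c1n[nH]cc1-c1ccccc1`: hydrogen in place of methyl on an aromatic carbon. The change is 4-methylphenyl to phenyl.

Among the compounds with values here, with compound 3 giving no number, no computed step exists for this pair. Since compound 1, with the same phenyl group, gives 57.5%, a move upward in this assay, beyond the scatter, is expected, though compounds 2 and 3 both being without number argues for caution. The value of compound 4 in this assay is estimated at 35%, expected between 0% and 65%.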

Compound 4, a percentage reported as activity, at one concentration (the size of the read-out at that concentration, not a potency): "not active" (no number reported)
Nothing numeric was reported for compound 4, and the estimate cannot be compared.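

Compound 3 and compound 4 both stand without a number in this assay, so no step can be read for the change from 4-methylphenyl to phenyl. No measured evidence bears on this result. The compounds shown leave open which structural feature goes with a numeric read-out, since only compound 1 gives one, 57.5%.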